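The compounds below may be only part of what the source reports. "The series", "measured", "known", "first", "only" and "open" are said of these compounds alone.

Measured so far:
- compound 1 `COc1cc(-c2ccnc3cc(-c4ccc(C)cc4)nn23)cc(OC)c1OC`: 21 nM
- compound 2 `Cn1ccc2cc(-c3cc4nccc(-c5ccc(F)cc5)n4n3)ccc21`: 5210 nM
- compound 3 `COc1ccc(-c2cc3nccc(-c4cc(OC)c(OC)c(OC)c4)n3n2)cc1[N+](=O)[O-]`: > 10000 nM

In a functional assay on HeLa cells (Homo sapiens) for inhibition, read by CCK-8 assay, with a stated time of 48 h (on this read-out lower numbers stand for stronger inhibition and higher numbers for weaker inhibition), compound 1 gives 21 nM, the lowest of the two numbers available. Compound 2 gives 5210 nM in this assay, a far higher number, well beyond the scatter. For compound 3 this assay reports only a limit, > 10000 nM; it sits at the limit of > 10000 nM in this assay, at which 1 of the 3 values shown sits, and is not a number. Among the measured compounds shown here, no step between measured compounds differing in one place is available, so the series offers no measured guide to any single change.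

Compound 4 `COc1cc(-c2ccnc3cc(-c4ccc(C(C)=O)cc4)nn23)cc(OC)c1OC` is not yet measured. It differs from compound 1 in one place: acetyl in place of methyl on an aromatic carbon. The shared core, the trimethoxyphenyl part and the ring bearing the change remain as in compound 1. For the measured compounds named here, with no comparable step measured, the expectation rests on compound 1 alone and on a modest step of a 2.9-fold higher number from compound 1 to compound 4 (0.46 log units; beyond the scatter) being estimated, toward a somewhat higher number, possibly no more than the scatter. Compound 4 is expected to give about 60 nM in this assay, within a range from 15 nM to 400 nM.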

Compound 4, half-maximal inhibitory concentration: 1810 nM
Estimate against measurement, compound 4: 30-fold (1.48 log units) below, and the stated range ends below it.
By their numbers in this assay, from the lowest: compound 1; then compound 4; then compound 2. At a limit, above all of these: compound 3.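

In this assay, among the compounds shown here, the exchange of 4-methylphenyl for 4-acetylphenyl gives an 86-fold higher number from compound 1 to compound 4 (1.94 log units; beyond the scatter), the first single-place change that can be read. This position, on the six-membered aromatic ring of carbon only and para to a large group, is therefore far from indifferent: with the shared core and the trimethoxyphenyl part unchanged, methyl and acetyl here give clearly different numbers. Nothing shown gives a cause for this step.

As far as these compounds go, whether the step follows the carbonyl or simply the larger group remains open, and an ethyl group at this place would help to separate the two. Also open, from the compounds shown here alone, is how far this position tolerates other groups, such as an amine or a carboxylic acid.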